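A few compounds are considered here, and "the series" means these few. Any claim that something is new, unique, unknown or untested is made for them only; others in the source may bear on it.

Measured compounds:
compound 1 `Cc1ccc(Nc2nc(N)nc(COc3ccc4c(C)cc(=O)oc4c3)n2)cc1` gives 1790 nM
compound 2 `Cc1cc(=O)oc2cc(OCc3nc(N)nc(Nc4ccc(C5CC5)cc4)n3)ccc12` gives 700 nM
compound 3 `Cc1cc(=O)oc2cc(OCc3nc(N)nc(Nc4ccc(C(C)C)cc4)n3)ccc12` gives 460 nM

In an assay on COS-7 cells for agonist activity at Free fatty acid receptor 1 (Homo sapiens), read by scintillation counting and inositol phosphate accumulation, with a stated time of 90 min (on this read-out lower numbers stand for an effect already at smaller amounts and higher numbers for an effect only at larger amounts of compound), compound 1 stands at the highest number of the three. Compound 4 `Cc1ccc(Nc2nc(N)nc(COc3ccc4c(C)cc(=O)oc4c3)n2)cc1Cl` differs from it by chloro in place of hydrogen on an aromatic carbon. Going by the values given here, no measured pair shows this exact change. The two steps that touch the same ring, a 2.6-fold lower number from compound 1 to compound 2 (0.41 log units; beyond the scatter) and a 3.9-fold lower number from compound 1 to compound 3 (0.59 log units; beyond the scatter), both enlarge the methyl group itself and both give modest gains, so a larger group on that ring has so far helped. A chloro entering ortho to the methyl group is a different place, so the expected step of a 1.8-fold lower number from compound 1 to compound 4 (0.25 log units; within the scatter) is small and uncertain, leaning towards a lower number. Compound 4 is therefore estimated at 1000 nM, between 400 nM and 2500 nM.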

Compound 4, half-maximal effective concentration: 140 nM
The estimate for compound 4 lay 7.1-fold (0.85 log units) above the measured number, outside the stated range (below it).
By their numbers in this assay, from the lowest: compound 4; then compounds 3 and 2 (each within the scatter of the next); then compound 1.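

In this assay, going by these compounds alone, a single chloro ortho to the methyl group gives a 13-fold lower number from compound 1 to compound 4 (1.11 log units; beyond the scatter), so this position, untouched in the earlier compounds, can strongly change the number. Keeping the methyl group and adding chloro also beats both larger groups, with a 3.3-fold lower number from compound 3 to compound 4 (0.52 log units; beyond the scatter) and a 5.0-fold lower number from compound 2 to compound 4 (0.70 log units; beyond the scatter). Nothing shown explains why this one atom has such an effect. The compounds shown leave open whether the gain is particular to chloro or would also come with fluoro, bromo or methoxy in the same place. They also leave open whether chloro would give a similar step alongside the isopropyl group of compound 3.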